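The compounds below may be only part of what the source reports. "The series", "measured", "known", "first", "only" and "open" are said of these compounds alone.

Measured in a functional assay on cells (+SA cell, Mus musculus) for cytotoxicity, read by MTT assay, with a stated time of 24 h; a lower number here means a stronger inhibitor, a higher number a weaker inhibitor:
- compound 1 `CC(C)=CCC/C(C)=C/CC/C(C)=C/CC[C@]1(C)CCc2c(C)c(OC(=O)c3ccc(C(=O)O)cc3C(=O)O)c(C)c(C)c2O1`: 1500 nM
- compound 2 `CC(C)=CCC/C(C)=C/CC/C(C)=C/CC[C@]1(C)CCc2cc(OC(=O)c3ccc(C(=O)O)cc3C(=O)O)c(C)c(C)c2O1`: 620 nM

Within the data shown here, compound 2, at 620 nM, holds the lowest of the two numbers so far. The next compound is compound 3 `CC(C)=CCC/C(C)=C/CC/C(C)=C/CC[C@]1(C)CCc2cc(OC(=O)c3ccccc3)c(C)c(C)c2O1`, not yet measured, and its difference from compound 2 is phenyl in place of 2,4-dicarboxyphenyl on a carbonyl carbon. This places phenyl in place of 2,4-dicarboxyphenyl on a carbonyl carbon.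

Among the measured compounds shown here, the only measured step is a 2.4-fold lower number from compound 1 to compound 2 (0.38 log units; beyond the scatter). It is modest but beyond the scatter, and it comes from hydrogen in place of methyl on an aromatic carbon. That step does not touch the group changing here, and every measured compound carries 2,4-dicarboxyphenyl, so it offers only a rough scale. The data fix no direction for this change. A modest move in this assay toward a higher number is expected, on the weak ground that compound 2 at 620 nM is the lowest so far. The expected change is a 2.4-fold higher number from compound 2 to compound 3 (0.38 log units; beyond the scatter). For compound 3 the estimated value is 1500 nM, with an expected range from 400 nM to 6000 nM.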

Compound 3, half-maximal inhibitory concentration: 6550 nM
Estimate against measurement, compound 3: 4.4-fold (0.64 log units) below; measured number above the stated range.
By their numbers in this assay, from the lowest: compound 2; then compound 1; then compound 3.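

In this assay, among these compounds, this is the first measured change at the group on the carbonyl carbon, and an 11-fold higher number from compound 2 to compound 3 (1.02 log units; beyond the scatter) shows that the number responds to replacing 2,4-dicarboxyphenyl with phenyl even though an aromatic ring stays in place. This step is larger than a 2.4-fold lower number from compound 1 to compound 2 (0.38 log units; beyond the scatter), so among the compounds shown, the group on the carbonyl carbon moves the number more than hydrogen in place of methyl on an aromatic carbon does. No measurement on hand bears on why the number rises.

Going by these compounds, the two carboxylic acid groups leave together, so it remains open whether a phenyl carrying a single carboxylic acid would stay close to compound 2, and whether an amide, a hydroxyl or a longer chain ending in a carboxylic acid could stand in for 2,4-dicarboxyphenyl. Among the compounds shown here, the change is also seen in only one pair, with hydrogen on the aromatic carbon, so it remains open whether phenyl would have a similar effect on the core of compound 1, which carries a methyl there.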